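Cytotoxicity of three carbonate prodrugs and a hydroxy analogue

The source may hold more compounds than are shown below. What is called first, only, known or untested is meant among the compounds shown, and "the series" means these compounds.

Compound 1, `Cc1cn(C2CC(N=[N+]=[N-])C(COC(=O)OCCCCCCCCO)O2)c(=O)[nH]c1=O`: in a functional assay on MT4 cells (Homo sapiens) for cytotoxicity (a lower number here means that less compound is tolerated, a higher number that more compound is tolerated), compound 1 gives > 50000 nM, which is a limit of the assay and not a number.
Compound 2, `Cc1cn(C2CC(N=[N+]=[N-])C(COC(=O)OCCCC(=O)OC(C)(C)C)O2)c(=O)[nH]c1=O`: in this assay compound 2 gives > 50000 nM, again a limit.
Compound 3, `Cc1cn(C2CC(N=[N+]=[N-])C(COC(=O)OCCCN)O2)c(=O)[nH]c1=O`: in this assay compound 3 gives > 50000 nM, also a limit.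

Compound 3 thus stands exactly where the other two measured compounds stand, namely at the limit of > 50000 nM in this assay, at which 3 of the 3 values shown sit. The three steps among the measured compounds, a step that the two limits leave unreadable from compound 1 to compound 2, a step that the two limits leave unreadable from compound 1 to compound 3 and a step that the two limits leave unreadable from compound 2 to compound 3, cannot be read in size or direction: each compares one limit with another limit.

Compound 4, `Cc1cn(C2CC(N=[N+]=[N-])C(COC(=O)OCCCO)O2)c(=O)[nH]c1=O`, has not yet been measured. It differs from compound 3 by hydroxy in place of amino on a saturated chain carbon, three bonds along the chain from an oxygen next to a carbonyl group. Among the measured compounds shown here, no measured step with a readable size bears on this change; what the three measured compounds show is that quite different groups at this position all sit at the same limit. The expected step that the limit leaves unreadable from compound 3 to compound 4 in this assay is therefore none beyond the scatter, and the most likely outcome for compound 4 is again a limit rather than a number. Compound 4 is estimated at 60000 nM, with a range from 30000 nM to 150000 nM.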

Compound 4, half-maximal cytotoxic concentration: > 50000 nM
Compound 4 was reported as a limit; the forecaster's own chance of this, stated with the estimate: 85%; the middle value does not contradict the limit.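

In this assay compound 4 gives > 50000 nM, which is a limit of the assay and not a number. Its steps from compound 1, compound 2 and compound 3 cannot be read in size or direction, since all four compounds end at the same limit: the limit of > 50000 nM in this assay, at which 4 of the 4 values shown sit.

The compounds shown leave open where the true value of each lies beyond this limit, and so whether the different groups on the chain change cytotoxicity at all.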